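Swapping a chlorophenyl for a cyclobutyl on the amide side chain

The source may hold more compounds than are shown below. What is called first, only, known or untested is meant among the compounds shown, and "the series" means these compounds.

The series shares one core, seen in compound 1 `Cc1cc(CN2C(=O)C(C3=NS(=O)(=O)c4cc(NS(C)(=O)=O)ccc4N3)=C(O)[C@H]3CCC[C@H]32)ccc1F`, compound 2 `CS(=O)(=O)Nc1ccc2c(c1)S(=O)(=O)N=C(C1=C(O)C3CCCC3N(Cc3ccc(Cl)cc3)C1=O)N2` and compound 3 `CS(=O)(=O)Nc1ccc2c(c1)S(=O)(=O)N=C(C1=C(O)[C@@H]3CCCC[C@@H]3N(Cc3ccc(F)cc3)C1=O)N2`. In an in vitro ADME assay on microsomes from liver (Homo sapiens) for metabolic stability (a higher number here means that the compound lasts longer, a lower number that the compound disappears faster), compound 1 gives > 1 h, a limit of the assay rather than a number. In this assay compound 2 likewise reaches > 1 h, again a limit. Compound 3 also sits at > 1 h in this assay, a limit. So compound 2 stands where every measured compound stands, at the limit of > 1 h in this assay, at which 3 of the 3 values shown sit, and no pair of measured compounds differs in one place, so no measured step is available.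

Compound 4 `CS(=O)(=O)Nc1ccc2c(c1)S(=O)(=O)N=C(C1=C(O)C3CCCC3N(CC3CCC3)C1=O)N2` is not yet measured. It differs from compound 2 by cyclobutyl in place of 4-chlorophenyl on a saturated chain carbon bound to an amide-type nitrogen in a ring. Going by the values given here, with no measured step to lean on, the expectation for compound 4 rests on the three values at the limit and on the size of the change. The step from compound 2 to compound 4 is expected to be a step that the limit leaves unreadable from compound 2 to compound 4, none beyond the scatter. Compound 4 is therefore estimated at 1.2 h in this assay, between 0.5 h and 3 h, most likely reported again as a limit.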

Compound 4, half-life: 0.0667 h
For compound 4 the middle estimate is 18-fold (1.26 log units) above the measured one; the whole stated range lies above it.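

Exchanging 4-chlorobenzyl for cyclobutylmethyl gives an at least 14-fold lower number from compound 2 to compound 4 (1.17 log units; beyond the scatter) in this assay, so the group on the saturated chain carbon bound to an amide-type nitrogen in a ring is not indifferent for this read-out. Compound 4, at 0.0667 h, is the only compound shown with a number rather than a limit, and it marks the first measurable loss of stability in the series. The earlier compounds could not reveal this, and the full size of the step remains unknown, since its starting point is only a limit: the limit of > 1 h in this assay, at which 3 of the 4 values shown sit.

The compounds shown do not separate the loss of the aromatic ring from the loss of the chlorine, as the single step changes both. Nor do they tell how an unsubstituted benzyl, a cyclohexylmethyl or a longer alkyl chain would behave at this place.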